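A few compounds are considered here, and "the series" means these few. Any claim that something is new, unique, unknown or untested is made for them only; others in the source may bear on it.

Measured in an ADME assay on Caco-2 cells (Homo sapiens) for permeability, in the apical to basolateral direction; on this read-out lower numbers stand for lower permeability and higher numbers for higher permeability:
Compound 1 `COC(=O)N[C@H](C(=O)NN(CCC[C@@](O)(Cc1ccccc1)C(=O)N[C@H]1c2ccccc2C[C@H]1O)Cc1ccc(-c2nccs2)cc1)C(C)(C)C`: > 20 10^-6 cm/s, a limit of the assay
Compound 2 `COC(=O)N[C@H](C(=O)NN(CCC[C@@](O)(Cc1ccccc1)C(=O)N[C@H]1c2ccccc2C[C@H]1O)Cc1ccc(-c2ccccc2)cc1)C(C)(C)C`: > 20 10^-6 cm/s, a limit of the assay

On this read-out compound 2 has no exact number. In this assay compound 2 gives > 20 10^-6 cm/s, which is a limit.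

Compound 3 `COC(=O)N[C@H](C(=O)NN(CCC[C@@](O)(Cc1ccccc1)C(=O)N[C@H]1c2ccccc2C[C@H]1O)Cc1ccc(-c2cccnc2)cc1)C(C)(C)C` keeps the core of compound 2 and puts pyridin-3-yl in place of phenyl on an aromatic carbon, para to a large group: pyridin-3-yl in place of phenyl on an aromatic carbon.

Within the data shown here, one measured step bears on this change, as it also exchanges the group at this place: a step that the two limits leave unreadable from compound 1 to compound 2. Its size cannot be read because of the limit of > 20 10^-6 cm/s in this assay, at which 2 of the 2 values shown sit. That step therefore gives no size to carry over, and it shows no fall for the exchange of 1,3-thiazol-2-yl and phenyl. In this assay no step beyond the scatter is therefore expected, and the estimated step reads a step that the limit leaves unreadable from compound 2 to compound 3. The expected value for compound 3 is 22 10^-6 cm/s. The estimated range for compound 3 runs from 10 10^-6 cm/s to 40 10^-6 cm/s.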

Compound 3, apparent permeability: < 20 10^-6 cm/s
Compound 3 ended at the assay's limit; the forecaster's own chance of this, stated with the estimate: 55%; middle value at least 1.1-fold (0.04 log units) away from the limit.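

In this assay, compound 3 gives < 20 10^-6 cm/s, which is a limit of the assay and the first in this series to carry this sign. At this place, on an aromatic carbon para to a large group, swapping the outer ring for pyridin-3-yl, which brings one ring nitrogen and one hydrogen-bond acceptor, now gives a direction where the earlier exchange gave none: a number no higher from compound 2 to compound 3 (the limit leaves the size open), and a number no higher from compound 1 to compound 3 (the limit leaves the size open). Neither size can be read, so the result shows that the change does not raise the number, but it does not establish a fall, as all the values shown sit at a single figure, with the limit on either side of it: the limit of > 20 10^-6 cm/s in this assay, at which 2 of the 3 values shown sit.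

The compounds shown leave open how far compound 3 actually lies from compound 2 and compound 1, as no exact number is available for any of them. They also leave open whether a pyridin-4-yl group at this place, with its ring nitrogen elsewhere, or a morpholine in place of the outer ring, would read as compound 3 does.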